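Hydroxy for fluoro on the aryl arm of compound 1

This account rests on a few compounds, and the source may have more. Where it says the series, first, only, none or still open, it means among the compounds named here.

Compound 1 `CCN(CC)CCCN(C(=O)c1ccc(-c2ccccc2)[nH]1)C(C(=O)NC1CCCCC1)c1ccc(F)cc1`: 1290 nM
Compound 2 `CCN(CC)CCCN(C(=O)CCN1CCCc2ccccc21)C(C(=O)NC1CCCCC1)c1ccc(F)cc1`: 2030 nM

In an assay on isolated protein for binding affinity to growth hormone secretagogue receptor type 1 (Homo sapiens) (a higher number here means a weaker inhibitor, a lower number a stronger inhibitor), compound 1 gives 1290 nM, the lower of the two numbers; compound 2 gives 2030 nM, and the step of a 1.6-fold higher number from compound 1 to compound 2 (0.20 log units; within the scatter) stays within the scatter. Compound 3 `CCN(CC)CCCN(C(=O)c1ccc(-c2ccccc2)[nH]1)C(C(=O)NC1CCCCC1)c1ccc(O)cc1` differs from compound 1 by hydroxy in place of fluoro on an aromatic carbon. Within the data shown here, neither measured step touches this position, so no direct precedent exists. The expectation for compound 3 is therefore a step of a 1.2-fold higher number from compound 1 to compound 3 (0.07 log units; within the scatter), no larger than the scatter in either direction. Compound 3 is estimated at 1500 nM, within a range of 500 nM to 4500 nM.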

Compound 3, inhibition constant: 1320 nM
The estimate for compound 3 lay 1.1-fold (0.06 log units) above the measured number; low and high end bracket the measured number.
By their numbers in this assay, from the lowest: compounds 1, 3 and 2 (each within the scatter of the next).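

In this assay, among these compounds, the change from 4-fluorophenyl to 4-hydroxyphenyl gives a 1.0-fold higher number from compound 1 to compound 3 (0.01 log units; within the scatter) and is the first measured step at this position. Here, hydroxy brings a hydrogen-bond donor and a hydrogen-bond acceptor that fluoro lacks, yet compound 1 and compound 3 read alike. No measured evidence bears on why this is so.

Going by these compounds, whether an amine or a methoxy group at this position would also read alike remains open. So does whether the same exchange would hold on compound 2, with its 2-(1,2,3,4-tetrahydroquinolin-1-yl)ethyl group.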